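A few compounds are considered here, and "the series" means these few. Any claim that something is new, unique, unknown or untested is made for them only; others in the source may bear on it.

Compound 1 `Nc1ccccc1NC(=O)c1ccc(CNC(=O)c2cc3cccnc3[nH]2)cc1`: 6100 nM
Compound 2 `Nc1ccccc1NC(=O)c1ccc(NC(=S)NCc2ccc(Cl)nc2)cc1`: 19000 nM
Compound 3 `Nc1ccccc1NC(=O)c1ccc(NC(=O)/C(Cl)=C(\Cl)c2cccnc2)cc1`: 560 nM

All three values come from a functional assay on HepG2 cells (Homo sapiens) for cytotoxicity, read by MTT assay, with a stated time of 72 h; a higher number here means a weaker inhibitor, a lower number a stronger inhibitor. Compound 2, at 19000 nM, has the highest number of the three, which makes it the weakest inhibitor of the set. Its gaps to the other two both lie beyond the usual scatter, and the wider gap is to compound 3, at 560 nM. Compound 1 falls in between at 6100 nM. Among the measured compounds shown here, the three compounds share a core but differ in more than one place, so no measured pair shows what a single change does.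

Compound 4 `Nc1ccccc1NC(=O)c1ccc(NC(=S)NCc2cncc(Br)c2)cc1` is a closer relative of compound 2, differing from it in one place only: 5-bromopyridin-3-yl in place of 6-chloropyridin-3-yl on a saturated chain carbon bound to an amide-type nitrogen. The swap, 5-bromopyridin-3-yl in place of 6-chloropyridin-3-yl, sits on a saturated chain carbon bound to an amide-type nitrogen. Both groups are a six-membered aromatic ring with 1 hetero atom and no net charge, and the rest of the molecule stays the same. The expectation therefore starts from compound 2 at 19000 nM, and no step beyond the scatter is expected in this assay. The expected step of a 1.4-fold lower number from compound 2 to compound 4 (0.13 log units; within the scatter) is small and leans slightly towards a lower number. The estimated value for compound 4 is 14000 nM, with an expected range of 5000 nM to 35000 nM.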

Compound 4, half-maximal inhibitory concentration: 7500 nM
The estimate for compound 4 lay 1.9-fold (0.27 log units) above the measured number, within the range that was stated.
By their numbers in this assay, from the lowest: compound 3; then compounds 1 and 4 (each within the scatter of the next); then compound 2.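

In this assay, among the compounds shown here, this is the first comparison that changes only one place, and 5-bromopyridin-3-yl in place of 6-chloropyridin-3-yl gives a 2.5-fold lower number from compound 2 to compound 4 (0.40 log units; beyond the scatter). The step is modest, but it shows that the group on this saturated chain carbon can affect the read-out even when the incoming and outgoing groups match in heavy atoms, ring type and counted hydrogen-bond donors and acceptors. Nothing available explains the difference between these two groups.

The swap changes both the halogen and the number that marks its place in the group's name, so this single step cannot show which of the two changes matters, and a plain pyridin-3-yl group with no halogen would show how much either halogen contributes at all. The compounds shown also leave open whether the same swap would give a similar step on a different linker, since compound 1 and compound 3 differ from compound 4 in more than one place and cannot be compared with it directly.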